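Changing the Group on Sulfur in Compound 3

The compounds below may be only part of what the source reports. "The series", "measured", "known", "first", "only" and "open" are said of these compounds alone.

Within the data shown here, three related compounds have numbers so far in a functional assay on A549 cells (Homo sapiens) for antiproliferative activity, read by MTT assay, with a stated time of 72 h; a lower number here means a stronger inhibitor, a higher number a weaker inhibitor. Compound 3 (`CC(C)(C)OC(=O)N1CCN(C(=S)Sc2ccc(F)cc2)CC1`) gives 1560 nM. Compound 1 (`S=C(Sc1ccccc1)N1CCOCC1`) gives 2520 nM, and these two values lie within the usual scatter of each other. Compound 2 (`CCCCN(CCCC)C(=S)Sc1ccccc1`) gives 9760 nM, a higher number that lies beyond the scatter when set against compound 3. Compound 3 therefore shares the lower end of this small set with compound 1.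

The next compound is compound 4 (`Cc1ccc(C)c(SC(=S)N2CCN(C(=O)OC(C)(C)C)CC2)c1`), which differs from compound 3 in one place: 2,5-dimethylphenyl in place of 4-fluorophenyl on a sulfur. Put simply, 2,5-dimethylphenyl takes the place of 4-fluorophenyl on a sulfur, and the rest of the molecule stays the same.

Among the measured compounds shown here, no two measured compounds differ in only one place, so the data do not show directly what a swap like this does. The incoming group still has one six-membered aromatic ring of carbon only, so a large change seems unlikely, although that remains a judgement. The estimated change, a 1.3-fold higher number from compound 3 to compound 4 (0.11 log units; within the scatter), is expected to stay within the scatter. For compound 4 the expected value is 2000 nM, with an estimated range of 700 nM to 6000 nM.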

Compound 4, half-maximal inhibitory concentration: 539 nM
Compound 4: the middle estimate sits 3.7-fold (0.57 log units) above what was measured, outside the stated range (below it).
By their numbers in this assay, from the lowest: compound 4; then compounds 3 and 1 (each within the scatter of the next); then compound 2.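

Among these compounds, this is the first pair in the set that differs in only one place, and in this assay it gives a 2.9-fold lower number from compound 3 to compound 4 (0.46 log units; beyond the scatter), so the group on this sulfur can move the number beyond the scatter. The two groups have the same ring type, the same hydrogen-bond donor and acceptor counts and no net charge, so a swap that leaves all of these unchanged can still produce a real step at this position, which compounds 1 and 2 could not show. Nothing measured here says why the number moves.

The compounds shown leave open whether the step goes with the loss of the fluorine or the arrival of the two methyl groups, as a plain phenyl on this sulfur appears only in compound 1 and compound 2, which also differ from compound 3 elsewhere in the molecule. Also open, going by these compounds, is how the number would respond to a group of another kind on this sulfur, such as a benzyl group, a pyridine ring or a hexyl chain.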